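The source may hold more compounds than are shown below. What is called first, only, known or untested is meant among the compounds shown, and "the series" means these compounds.

Measured so far in a functional assay on SiHa cells (Homo sapiens) for antiproliferative activity, read by CCK-8 assay, with a stated time of 72 h; on this read-out higher numbers stand for weaker inhibition and lower numbers for stronger inhibition:
- compound 1 `COc1cc(-c2ncncc2-c2ccc(SC)cc2)cc(OC)c1OC` gives 560 nM
- compound 2 `COc1cc(-c2ncncc2-c2ccc(OC(C)C)cc2)cc(OC)c1OC` gives 9970 nM

Among the compounds with values here, compound 1 holds the lower of the two numbers in this assay ; the only other measured compound, compound 2, lies an 18-fold higher number from compound 1 to compound 2 (1.25 log units; beyond the scatter) from it, and that is the one measured step in the set.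

Compound 3 `COc1cc(-c2ncncc2-c2ccc3cc[nH]c3c2)cc(OC)c1OC` is not yet measured. Relative to compound 1 the change is 1H-indol-6-yl in place of 4-(methylsulfanyl)phenyl on an aromatic carbon. The measured step bears on this only indirectly: an 18-fold higher number from compound 1 to compound 2 (1.25 log units; beyond the scatter) shows that a change to the group on that ring can move the number far beyond the scatter, so the position is sensitive, but nothing measured tells whether 1H-indol-6-yl, with its hydrogen-bond donor and added five-membered ring, follows the methylsulfanyl of compound 1 or the isopropoxy of compound 2. Given a donor entering where an acceptor leaves, a step toward a higher number is expected, though probably not as large as the measured one. Compound 3 is therefore estimated at 1800 nM, with a range from 350 nM to 9000 nM. That estimate means an expected step of a 3.2-fold higher number from compound 1 to compound 3 (0.51 log units; beyond the scatter).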

Compound 3, half-maximal inhibitory concentration: 2180 nM
Beside the measured number, compound 3's estimate is 1.2-fold (0.08 log units) below it, and the stated range covers the measured number.
By their numbers in this assay, from the lowest: compound 1; then compound 3; then compound 2.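

In this assay, a 3.9-fold higher number from compound 1 to compound 3 (0.59 log units; beyond the scatter) is a modest step but lies beyond the scatter, and it comes from replacing the whole 4-(methylsulfanyl)phenyl group rather than only the group carried on that phenyl ring. The position on the six-membered aromatic ring with 2 nitrogen therefore accepts 1H-indol-6-yl, with its five-membered aromatic ring and hydrogen-bond donor, at a moderate cost: compound 3 gives 2180 nM, while the isopropoxy-bearing compound 2 gives the higher 9970 nM. Nothing available accounts for the rise from compound 1 to compound 3.

The compounds shown do not separate the contribution of the indole hydrogen on nitrogen from that of the added ring, a question that 1-methyl-1H-indol-6-yl or benzofuran-6-yl would address directly. Also open, on these data alone, is whether compound 1's lower number is specific to methylsulfanyl, or whether a 4-methoxyphenyl, 4-ethylsulfanylphenyl or 4-aminophenyl group at the same place would stay near compound 1 or move toward compound 2.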